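The compounds below may be only part of what the source reports. "The series", "measured", "known", "first", "only" and "open" are said of these compounds alone.

Compound 1 `Oc1cc(-c2ccccc2)nc2c(O)cccc12` — > 10 ug/mL
Compound 2 `CS(=O)(=O)Oc1cc(-c2ccccc2)nc2ccccc12` — 5.6 ug/mL
Compound 3 `COc1ccc2nc(-c3ccccc3)cc(O)c2c1` — 1 ug/mL

Three compounds sharing one core have been run in a functional assay on HCT-8 cells (Homo sapiens) for cytotoxicity; a higher number here means that more compound is needed for the effect, a lower number that less compound is needed. For compound 1 the assay reports only a limit, > 10 ug/mL, and no number. Among the two numbers that remain, compound 2 stands highest with 5.6 ug/mL in this assay. Compound 3, with its methoxy group on the core and a free hydroxyl, gives the lower number, 1 ug/mL, a difference that lies beyond the usual scatter. Among the measured compounds shown here, no pair of these three compounds differs in only one place, so no single step can be read from them.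

Compound 4 `CCCOc1cc(-c2ccccc2)nc2ccccc12` has not yet been measured. It follows from compound 2 by one change, (propyl in place of methylsulfonyl on an oxygen on an aromatic ring). Neither compound 1 nor compound 3 carries a group of this kind on that oxygen, so the measured values offer no direct guide for the size of the step. A step of this kind from compound 2 to compound 4 is expected to stay within the scatter, or at most to turn out slightly toward a lower number: a 1.4-fold lower number from compound 2 to compound 4 (0.15 log units; within the scatter). Compound 4 is therefore expected to give about 4 ug/mL in this assay, with a range from 1.5 ug/mL to 10 ug/mL.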

Compound 4, half-maximal effective concentration: > 10 ug/mL
Compound 4: only a limit was reported (the forecaster's own chance of this, stated with the estimate: 15%); middle value at least 2.5-fold (0.39 log units) away from the limit.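

For compound 4, this assay reports only a limit, > 10 ug/mL. Among the compounds shown here, putting propyl in place of methylsulfonyl on an oxygen on an aromatic ring gives the first step that can be read at this place on the shared core, an at least 1.7-fold higher number from compound 2 to compound 4 (0.25 log units; that floor lies within the scatter), so the change does not bring the number down, although its floor alone does not establish a rise beyond the scatter. The true size of the step stays unknown, and the data fix only its lower bound, set by the end of the range reported: the limit of > 10 ug/mL in this assay, at which 2 of the 4 values shown sit.

The compounds shown leave open how far compound 4 really lies from compound 2, and so whether this change matters more than repeated measurements would scatter. They also leave open what a longer chain, a chain ending in an amine, or a carboxylic acid on this same oxygen would give, and whether methylsulfonyl behaves differently from such groups on an oxygen elsewhere on the core.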